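Trimethoxyphenyl benzylamines: amide carbonyl substituent step

A few compounds are considered here, and "the series" means these few. Any claim that something is new, unique, unknown or untested is made for them only; others in the source may bear on it.

Compound 1 `COc1cc(NCc2ccc(Cl)cc2)cc(OC)c1OC` is reported in a functional assay on MGC-803 cells (Homo sapiens) for inhibition, read by MTT assay, with a stated time of 48 h (a higher number here means a weaker inhibitor, a lower number a stronger inhibitor), only as a limit, > 80000 nM, and not as a number. That entry is the limit of > 80000 nM in this assay, at which 1 of the 3 values shown sits. Compound 2 `COc1ccc(CNc2cc(OC)c(OC)c(OC)c2)cc1Br` gives 29400 nM in this assay. Compound 3 `C#CC(=O)N(Cc1ccc(OC)c(O)c1)c1cc(OC)c(OC)c(OC)c1` gives 170 nM, the lowest of the two numbers; the nearest number, that of compound 2, lies well beyond the scatter from it.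

Compound 4 `COc1ccc(CN(C(=O)CCCCCl)c2cc(OC)c(OC)c(OC)c2)cc1O` differs from compound 3 by 4-chlorobutyl in place of ethynyl on a carbonyl carbon. Within the data shown here, no measured pair covers this change, so the expectation rests on direction only: a loss of potency, with the step from compound 3 expected to be a 15-fold higher number from compound 3 to compound 4 (1.17 log units; beyond the scatter), beyond the scatter. Compound 4 is therefore estimated at 2500 nM, with a range from 500 nM to 15000 nM in this assay.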

Compound 4, half-maximal inhibitory concentration: 540 nM
Beside the measured number, compound 4's estimate is 4.6-fold (0.67 log units) above it; the measured number falls inside the stated range.
By their numbers in this assay, from the lowest: compound 3; then compound 4; then compound 2. At a limit, above all of these: compound 1.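

At this carbonyl carbon, whose other neighbour is the amide-type nitrogen, 4-chlorobutyl in place of ethynyl gives in this assay a 3.2-fold higher number from compound 3 to compound 4 (0.50 log units; beyond the scatter) and counts as a modest loss. The triple bond is therefore not required for activity of this order in the series, and a longer chlorine-bearing chain is accepted at this place. Nothing shown accounts for the size of this step. Going by these compounds, whether the chlorine or the chain carries the result stays open. A plain butyl chain, a shorter chloropropyl chain or a terminal amine at the same carbon would separate these.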